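Arylamine substituent series: cytotoxicity notes toward compound 4

The compounds below may be only part of what the source reports. "The series", "measured", "known", "first", "only" and "open" are said of these compounds alone.

Measured in an ADME assay on cells (Homo sapiens) for cytotoxicity, read by polymerase chain reaction, with a stated time of 3 days; on this read-out higher numbers stand for lower toxicity in this test and lower numbers for higher toxicity in this test:
- compound 1 `Cc1nc(NC(C)C)nc(N[C@@H]2C[C@H](CO)[C@@H](O)[C@H]2O)c1-c1nc2ccccc2s1` gives 13000 nM
- compound 2 `Cc1nc(NCC(C)C)nc(N[C@@H]2C[C@H](CO)[C@@H](O)[C@H]2O)c1-c1nc2ccccc2s1` gives 10000 nM
- compound 3 `Cc1nc(Nc2ccccc2)nc(N[C@@H]2C[C@H](CO)[C@@H](O)[C@H]2O)c1-c1nc2ccccc2s1` gives > 25000 nM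

The value of compound 3 is a limit of the assay and not a number: the limit of > 25000 nM in this assay, at which 1 of the 3 values shown sits. Compound 3 is thus the only one of the three for which no point value is known.

Compound 4 `Cc1nc(NCc2ccccn2)nc(N[C@@H]2C[C@H](CO)[C@@H](O)[C@H]2O)c1-c1nc2ccccc2s1` has not been measured; it differs from compound 3 by (pyridin-2-yl)methyl in place of phenyl on a nitrogen on an aromatic ring. Going by the values given here, no measured step covers this exact change. The steps that touch the same nitrogen are an at least 1.9-fold higher number from compound 1 to compound 3 (0.28 log units; that floor lies within the scatter) and an at least 2.5-fold higher number from compound 2 to compound 3 (0.39 log units; beyond the scatter), both running toward the limit when phenyl replaced an alkyl group, while a 1.3-fold lower number from compound 1 to compound 2 (0.11 log units; within the scatter) shows the two alkyl groups apart by little. Whether the ((pyridin-2-yl)methyl)amino group behaves like the anilino group or like the alkylamino groups cannot be read from these three compounds, so the expected step of an at least 1.2-fold lower number from compound 3 to compound 4 (0.09 log units; that floor lies within the scatter) is set near zero with a wide range. Compound 4 is therefore expected to give 20000 nM in this assay, within 7000 nM to 50000 nM, with a fair chance that only a limit is reported again.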

Compound 4, half-maximal cytotoxic concentration: 13000 nM
Estimate against measurement, compound 4: 1.5-fold (0.19 log units) above; measured number inside the range.
By their numbers in this assay, from the lowest: compounds 2, 1 and 4 (each within the scatter of the next). At a limit, above all of these: compound 3.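

In this assay, the ((pyridin-2-yl)methyl)amino group reads with the alkylamino groups and not at the limit of the anilino group, with no change at the digits printed from compound 1 to compound 4 (within the scatter) and a 1.3-fold higher number from compound 2 to compound 4 (0.11 log units; within the scatter), so an aromatic ring in the substituent on this nitrogen does not by itself bring the limit. Against the anilino group the change gives an at least 1.9-fold lower number from compound 3 to compound 4 (0.28 log units; that floor lies within the scatter), and this floor does not yet show a gap beyond the scatter. Compound 3 remains a limit of the assay and not a number: the limit of > 25000 nM in this assay, at which 1 of the 4 values shown sits.

The compounds shown do not separate the ring nitrogen from the added chain carbon; a benzylamino or a pyridin-2-ylamino group on the same nitrogen would bear on that. From the compounds shown here alone, the true size of the step from the anilino group also stays open.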